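Meta-halogen swap on the pendant phenyl: fluoro to chloro

The source may report more compounds than this note shows. Statements on the series, on what has been measured and on what is new or still open speak of the compounds shown alone.

Three measured members of this series share one core and differ in the pendant aryl and the sulfonyl aryl. Compound 1 `O=S(=O)(c1ccc(F)c(F)c1)c1cnc2c(F)cccc2c1-c1ccc(Cl)cc1` gives 0.28 mL/min in an ADME assay on microsomes from liver (Homo sapiens) for metabolic stability, tested at 2.5 uM; a higher number here means faster removal of the compound, a lower number slower removal. Compound 2 `COc1ccc(S(=O)(=O)c2cnc3c(F)cccc3c2-c2cccc(Cl)c2)cc1` gives 2.75 mL/min in this assay. Compound 3 `O=S(=O)(c1ccc(F)c(F)c1)c1cnc2c(F)cccc2c1-c1cccc(F)c1` gives 1.28 mL/min in this assay, which places compound 3 second highest of the three, between compound 1 and compound 2, with both gaps beyond the scatter. Among the measured compounds shown here, the one single-point step recorded, a 4.6-fold higher number from compound 1 to compound 3 (0.66 log units; beyond the scatter), combines a change of halogen with a change of position, so it bears only loosely on the present question.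

Compound 4 `O=S(=O)(c1ccc(F)c(F)c1)c1cnc2c(F)cccc2c1-c1cccc(Cl)c1` differs from compound 3 by chloro in place of fluoro on an aromatic carbon. Compound 2 also carries a 3-chlorophenyl group but on a different sulfonyl aryl, so its value only shows that a 3-chlorophenyl member can sit at the higher end of this set. For the measured compounds named here, nothing among the measured steps isolates the chloro-for-fluoro exchange alone; given the small size of the change, compound 4 is expected to move little in this assay, and the step of a 1.2-fold lower number from compound 3 to compound 4 (0.07 log units; within the scatter) is estimated to fall near or within the scatter.

Compound 4 is therefore estimated at 1.1 mL/min in this assay, within a range of 0.4 mL/min to 2.8 mL/min.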

Compound 4, intrinsic clearance in a liver preparation (reported as CLH), per the amount of preparation that the assay uses: 1.13 mL/min
Compound 4: middle estimate off by 1.0-fold (0.01 log units), on the low side; measured number inside the range.
By their numbers in this assay, from the lowest: compound 1; then compounds 4 and 3 (each within the scatter of the next); then compound 2.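

In this assay, among the compounds shown here, the step of a 1.1-fold lower number from compound 3 to compound 4 (0.05 log units; within the scatter) is the first reading of 3-fluorophenyl to 3-chlorophenyl on its own, and it lies within the scatter, so at this place on the pendant ring the two halogens are not told apart. With chloro held constant, 3-chlorophenyl in place of 4-chlorophenyl gives a 4.0-fold higher number from compound 1 to compound 4 (0.61 log units; beyond the scatter) and the earlier mixed step (a 4.6-fold higher number from compound 1 to compound 3 (0.66 log units; beyond the scatter)) can now be read mainly as a matter of where the halogen sits and not of which halogen it is, at least among compounds 1, 3 and 4. With 3-chlorophenyl held constant, 3,4-difluorophenyl in place of 4-methoxyphenyl on the sulfonyl sulfur gives a 2.4-fold lower number from compound 2 to compound 4 (0.39 log units; beyond the scatter) and so the sulfonyl aryl also moves the number beyond the scatter.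

Still open, on these data alone, is whether a non-halogen group at the same place on the pendant ring, such as an amine or a nitrile, would stay level with compound 3 and compound 4, and whether the sulfonyl step repeats on the other pendant aryl groups. Nothing shown accounts for why the place of the chloro or the choice of sulfonyl aryl shifts the number.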